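Chloro to Bromo in a Small Antiproliferative Series

The source may hold more compounds than are shown below. What is called first, only, known or untested is meant among the compounds shown, and "the series" means these compounds.

In a functional assay on MCF7 cells (Homo sapiens) for antiproliferative activity, read by colorimetric assay and MTT assay, with a stated time of 48 h (a lower number here means a stronger inhibitor, a higher number a weaker inhibitor), compound 1 `O=C(NS(=O)(=O)c1ccccc1)c1cncc(C(=O)NS(=O)(=O)c2ccccc2)c1` gives 10600 nM, compound 2 `O=C(NS(=O)(=O)c1ccc(F)cc1)c1ccncc1` gives 13900 nM and compound 3 `O=C(NS(=O)(=O)c1ccc(Cl)cc1)c1ccncc1` gives 10100 nM. Compound 3 therefore stands level with the other two, as all three numbers lie within the scatter of one another. Compound 4 `O=C(NS(=O)(=O)c1ccc(Br)cc1)c1ccncc1` differs from compound 3 by bromo in place of chloro on an aromatic carbon. Within the data shown here, the one measured step that bears on this change is chloro in place of fluoro, a 1.4-fold lower number from compound 2 to compound 3 (0.14 log units; within the scatter), which is small and within the scatter. No step beyond the scatter is therefore expected in this assay. The expected step is a 1.1-fold lower number from compound 3 to compound 4 (0.03 log units; within the scatter). The estimate for compound 4 is 9500 nM, with an expected range from 5000 nM to 18000 nM.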

Compound 4, half-maximal inhibitory concentration: 8700 nM
For compound 4 the middle estimate is 1.1-fold (0.04 log units) above the measured one, within the range that was stated.
By their numbers in this assay, from the lowest: compounds 4, 3, 1 and 2 (each within the scatter of the next).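

In this assay this position on the aromatic ring now carries fluoro, chloro and bromo across compounds 2, 3 and 4, and neither a 1.2-fold lower number from compound 3 to compound 4 (0.06 log units; within the scatter) nor a 1.6-fold lower number from compound 2 to compound 4 (0.20 log units; within the scatter) leaves the scatter. Among these three compounds, exchanging one halogen for another here therefore gives no step beyond the scatter. Nothing shown offers an explanation for this result.

Going by these compounds, it remains open whether an amine, a methoxy group or a carboxylic acid at this position would give a step beyond the scatter. Also open, on these data alone, is whether the same halogen exchanges would behave alike on the core of compound 1.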